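Swapping the oxygen substituent in a shared core

The source may hold more compounds than are shown below. What is called first, only, known or untested is meant among the compounds shown, and "the series" means these compounds.

Of the compounds shown here, two built on one shared core have been tested in a functional assay on HEK293 cells for agonist activity at G-protein coupled receptor 39 (Homo sapiens), read by scintillation proximity assay and inositol phosphate accumulation, with a stated time of 75 min; a higher number here means that more compound is needed for the effect, a lower number that less compound is needed. Compound 1 `Cc1nn(-c2ncnc3nc[nH]c23)c2c1C(OCC(=O)c1ccc(F)cc1)CC(=O)N2` gives 973 nM in this assay. Among the compounds with values here, compound 2 `Cc1nn(-c2ncnc3nc[nH]c23)c2c1C(OC(=O)c1ccc(F)cc1)CC(=O)N2` gives 245 nM, and the single change between them, a 4.0-fold lower number from compound 1 to compound 2 (0.60 log units; beyond the scatter), is the only measured step so far. Compound 2 therefore stands at the lowest number of the two, with compound 1 the nearest neighbour.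

Compound 3 `Cc1nn(-c2ncnc3nc[nH]c23)c2c1C(OCc1ccccc1Cl)CC(=O)N2` differs from compound 2 by 2-chlorobenzyl in place of (4-fluorophenyl)carbonyl on an oxygen on a saturated carbon. Within the data shown here, the one measured step bears only loosely on this change: it showed that the group on this oxygen matters, and that its modest alteration shifted the number beyond the scatter. Nothing measured shows what removing the carbonyl acceptor and moving from a 4-fluoro to a 2-chloro substituent does. The expectation is a change a 2.0-fold higher number from compound 2 to compound 3 (0.31 log units; beyond the scatter), with a wide range. Compound 3 is estimated at 500 nM, between 150 nM and 2000 nM.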

Compound 3, half-maximal effective concentration: 47 nM
Estimate against measurement, compound 3: 11-fold (1.03 log units) above, outside the stated range (below it).
By their numbers in this assay, from the lowest: compound 3; then compound 2; then compound 1.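

In this assay, 2-chlorobenzyl in place of (4-fluorophenyl)carbonyl on this oxygen gives a 5.2-fold lower number from compound 2 to compound 3 (0.72 log units; beyond the scatter), which shows that a carbonyl in this group is not needed for a low number. Compared with the ((4-fluorophenyl)carbonyl)methyl group of compound 1, the same 2-chlorophenyl swap on the saturated chain carbon gives a 21-fold lower number from compound 1 to compound 3 (1.32 log units; beyond the scatter), the largest step so far, so the group on this oxygen can move the number a long way. No supporting measurement explains why these groups rank as they do.

On these data alone, the change from compound 2 to compound 3 alters the carbonyl and the halogen-bearing ring together, so the share of each remains unknown. A plain benzyl or a 4-fluorobenzyl group would separate the two, and an amine in the chain would test a different kind of group at this position.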